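Swapping Cyclopentyl for 1-(Methoxymethyl)ethyl

This account rests on a few compounds, and the source may have more. Where it says the series, first, only, none or still open, it means among the compounds named here.

In a physicochemical assay for lipophilicity, using the shake flask method (a lower number here means a more polar compound, a higher number a more lipophilic compound), compound 3 `CN(C)C(=O)c1ncc(Oc2cc(OC3CCCC3)cc(-c3nccc(=O)[nH]3)c2)cn1` gives 1.74. Among the measured compounds shown here, its only measured neighbour, compound 2 `CCC(CC)Oc1cc(Oc2cnc(C(=O)N(C)C)nc2)cc(-c2nccc(=O)[nH]2)c1`, gives 1.91, and these two numbers lie within the scatter of each other. The entry for compound 1 `CC(C)Oc1cc(Oc2ccc(S(C)(=O)=O)cc2)cc(-c2ncc(C(C)C)c(=O)[nH]2)c1` reads "not determined" (no result reported), so it offers no comparison. Compound 4 `COC[C@H](C)Oc1cc(Oc2cnc(C(=O)N(C)C)nc2)cc(-c2nccc(=O)[nH]2)c1` has yet to be measured. It differs from compound 3 in one place: 1-(methoxymethyl)ethyl in place of cyclopentyl on an oxygen on an aromatic ring. Put simply, 1-(methoxymethyl)ethyl stands in place of cyclopentyl on an oxygen on an aromatic ring, and the entering group holds an oxygen that cyclopentyl lacks.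

For the measured compounds named here, the one measured step, a number 0.17 log units lower from compound 2 to compound 3 (within the scatter), replaced pentan-3-yl with cyclopentyl. Going by the values given here, both groups contain carbon only, so that step says little here, and no measured step introduces such an oxygen. The size of the coming step therefore rests on judgement, though a move to a lower number in this assay, beyond the scatter, is expected. The expected change is a number 0.54 log units lower from compound 3 to compound 4 (beyond the scatter). Compound 4 is estimated at 1.2, with an expected range of 0.8 to 1.6.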

Compound 4, distribution coefficient: 0.43
For compound 4 the middle estimate is 0.77 log units above the measured one; measured number below the stated range.
By their numbers in this assay, from the lowest: compound 4; then compounds 3 and 2 (each within the scatter of the next).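

In this assay this place, on an oxygen on an aromatic ring, proves far more sensitive than compound 2 and compound 3 could show: their two all-carbon groups stand within the scatter of each other, whereas 1-(methoxymethyl)ethyl in place of cyclopentyl gives a number 1.31 log units lower from compound 3 to compound 4 (beyond the scatter) and the same group in place of pentan-3-yl gives a number 1.48 log units lower from compound 2 to compound 4 (beyond the scatter) in this small set. Pentan-3-yl has no ring either, so the large step also appears between two open groups, and it does not need the loss of a ring. Nothing available here gives a reason for the size of these steps.

The compounds shown leave open what a chain ending in a hydroxyl or an amine would give in this place. They also leave open how the opposite form of the defined stereocentre in 1-(methoxymethyl)ethyl would read.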